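The source may report more compounds than this note shows. Statements on the series, on what has been measured and on what is new or still open speak of the compounds shown alone.

Compound 1 `COc1cc(OC)c(/C=C/S(=O)(=O)Cc2ccc(OC)c(N)c2)c(OC)c1`: 2.5 nM
Compound 2 `COc1cc(OC)c(/C=C/S(=O)(=O)Cc2ccc(OC)c(N[C@@H](C)C(=O)O)c2)c(OC)c1`: 15 nM

Both values come from a functional assay on K562 cells (Homo sapiens) for cytotoxicity, read by trypan blue exclusion, with a stated time of 96 h; on this read-out higher numbers stand for weaker inhibition and lower numbers for stronger inhibition. Compound 2 has the higher of the two numbers, so it is the weaker inhibitor of the pair. The measured change is a 6.0-fold higher number from compound 1 to compound 2 (0.78 log units; beyond the scatter), a modest step beyond the usual scatter. It comes from placing 1-carboxyethyl in place of hydrogen on a nitrogen on an aromatic ring.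

Going by the values given here, the next compound, compound 3 `COc1cc(OC)c(/C=C/S(=O)(=O)Cc2ccc(OC)c(NC(C)(C)C(=O)O)c2)c(OC)c1`, alters only that group: 1-carboxy-1-methylethyl in place of 1-carboxyethyl on a nitrogen on an aromatic ring. In words, 1-carboxy-1-methylethyl stands in place of 1-carboxyethyl on a nitrogen on an aromatic ring.

Among the compounds with values here, only one measured step bears on this site, the modest 6.0-fold higher number from compound 1 to compound 2 (0.78 log units; beyond the scatter). That step replaced hydrogen with a whole group, whereas the new change only enlarges a group already there. Within the data shown here, no measured pair tests this smaller change directly, so the direction is uncertain. A small further rise in the number is expected, probably not beyond the scatter.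

The expected step in this assay is a 1.3-fold higher number from compound 2 to compound 3 (0.12 log units; within the scatter).

The estimate for compound 3 is 20 nM, with an expected range from 7 nM to 60 nM.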

Compound 3, half-maximal inhibitory concentration: 7.5 nM
The estimate for compound 3 lay 2.7-fold (0.43 log units) above the measured number; low and high end bracket the measured number.
By their numbers in this assay, from the lowest: compound 1; then compounds 3 and 2 (each within the scatter of the next).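

In this assay, 1-carboxy-1-methylethyl in place of 1-carboxyethyl on the nitrogen gives a 2.0-fold lower number from compound 2 to compound 3 (0.30 log units; within the scatter) and so the two side chains cannot be told apart here, even though the swap adds one carbon and removes the defined stereocentre. Both substituted compounds still separate from the compound with a plain hydrogen on that nitrogen: alongside the earlier step, the new comparison gives a 3.0-fold higher number from compound 1 to compound 3 (0.48 log units; beyond the scatter) and so shows that the rise in the number seen with 1-carboxyethyl is not confined to that one group. No measurement shown here explains these numbers.

Both substituents carry a carboxylic acid, so the compounds shown cannot separate the effect of the acid from that of the carbon branch that holds it; a plain isopropyl group on the nitrogen or a methyl ester of the acid would address this. Also open, as far as these compounds go, are the mirror-image form of 1-carboxyethyl and whether a longer chain between the nitrogen and the carboxylic acid would keep the number in this range.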